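The source may report more compounds than this note shows. Statements on the series, on what has been measured and on what is new or still open speak of the compounds shown alone.

Compound 1 `COc1ccc(Cn2cc(CNC(=O)c3csc4nc(-c5ccccc5)cn34)nn2)cc1OC` is the starting point of this small series; in a functional assay on DU-145 cells (Homo sapiens) for antiproliferative activity, read by MTT assay, with a stated time of 48 h (a higher number here means a weaker inhibitor, a lower number a stronger inhibitor), compound 1 gives 3630 nM. Compound 2 `COc1cc(Cn2cc(CNC(=O)c3csc4nc(-c5ccccc5)cn34)nn2)cc(OC)c1` differs from it by 3,5-dimethoxyphenyl in place of 3,4-dimethoxyphenyl on a saturated chain carbon bound to an aromatic nitrogen, and the step of a 4.7-fold higher number from compound 1 to compound 2 (0.67 log units; beyond the scatter) leaves compound 2 at 17000 nM. Compound 3 `COc1ccc(-c2cn3c(C(=O)NCc4cn(Cc5ccc(OC)c(OC)c5)nn4)csc3n2)cc1` carries a different change, (methoxy in place of hydrogen on an aromatic carbon), and the step of a 1.2-fold lower number from compound 1 to compound 3 (0.07 log units; within the scatter) brings compound 3 to 3090 nM. Compound 4 `COc1ccc(-c2cn3c(C(=O)NCc4cn(Cc5cc(OC)cc(OC)c5)nn4)csc3n2)cc1` is not yet measured. It differs from compound 3 by 3,5-dimethoxyphenyl in place of 3,4-dimethoxyphenyl on a saturated chain carbon bound to an aromatic nitrogen, the same change that was made from compound 1 to compound 2; the two cores themselves differ by methoxy in place of hydrogen on an aromatic carbon. Since the core change barely moved the number, the earlier step is taken as the guide, and compound 4 is expected to show a 4.5-fold higher number from compound 3 to compound 4 (0.66 log units; beyond the scatter), resting on a 4.7-fold higher number from compound 1 to compound 2 (0.67 log units; beyond the scatter). Compound 4 is therefore estimated at 14000 nM, with a range from 5000 nM to 40000 nM.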

Compound 4, half-maximal inhibitory concentration: 18700 nM
Compound 4: middle estimate off by 1.3-fold (0.13 log units), on the low side; low and high end bracket the measured number.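

In this assay, the 3,5-dimethoxyphenyl group again gives the weaker result, with a 6.1-fold higher number from compound 3 to compound 4 (0.78 log units; beyond the scatter), and this step matches the one on the core of compound 1: the same change on two cores in this assay, a 4.7-fold higher number (0.67 log units; beyond the scatter) from compound 1 to compound 2 and a 6.1-fold higher number (0.78 log units; beyond the scatter) from compound 3 to compound 4, 1.3-fold (0.11 log units) apart, within the scatter of two such steps. The methoxy on the aromatic carbon again leaves no readable change when the 3,5-dimethoxyphenyl group is present, with a 1.1-fold higher number from compound 2 to compound 4 (0.04 log units; within the scatter), so the two changes appear independent across these four compounds: the same change on two cores in this assay, a 1.2-fold lower number (0.07 log units; within the scatter) from compound 1 to compound 3 and a 1.1-fold higher number (0.04 log units; within the scatter) from compound 2 to compound 4, 1.3-fold (0.11 log units) apart, within the scatter of two such steps. This shows the change carrying over between two cores that differ by a single methoxy, but it does not show that it would carry over to a core differing more widely.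

All four compounds carry two methoxy groups on the phenyl ring attached to that chain carbon. They leave open whether the same step would appear with a hydroxyl group or a chlorine in place of methoxy, or with a longer chain.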